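The source may hold more compounds than are shown below. What is called first, only, known or untested is meant among the compounds shown, and "the series" means these compounds.

Compound 1, `Brc1ccccc1COc1nc2ccccc2s1`: 75.6%
Compound 2, `Brc1ccc(OCCOc2nc3ccccc3s2)c(Br)c1`: 87.3%

In a functional assay on the whole organism with Mus musculus as the target, with a stated time of 1 h, at a dose of 100 mg/kg by the intraperitoneal route (on this read-out lower numbers stand for less inhibition and higher numbers for more inhibition at the one dose given (going by the name of the read-out)), compound 2 gives 87.3%, the higher of the two numbers, and compound 1 gives 75.6%, a number that lies beyond the usual scatter below it. Compound 3, `Brc1ccc(OCCOc2nc3ccccc3s2)cc1`, has not yet been measured in this assay. Compared with compound 2 the change is hydrogen in place of bromo on an aromatic carbon. Among the compounds with values here, no step between measured compounds is known here to show what this change does. A modest drop is expected, at most slightly beyond the scatter, with an estimated step of a number 12.3 percentage points lower from compound 2 to compound 3 (beyond the scatter). Compound 3 is therefore expected to give about 75%, within a range from 55% to 90%.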

Compound 3, a percentage reported as inhibition, in the whole organism at one dose (the size of the read-out at that dose, not a potency): 94.6%
Compound 3: the middle estimate sits 19.6 percentage points below what was measured; the measured number lies above the stated range.
By their numbers in this assay, from the lowest: compound 1; then compounds 2 and 3 (each within the scatter of the next).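

In this assay, putting hydrogen in place of bromo on the aromatic carbon ortho to a large group gives a number 7.3 percentage points higher from compound 2 to compound 3 (within the scatter), so this change makes no difference that can be told from the scatter. At this one dose, this bromo is therefore not needed for a high read-out. Nothing measured here explains this result.

On these data alone, what an amine or a carboxylic acid at this place would do remains open. So does the role of the remaining bromo group.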